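The source may report more compounds than this note shows. Statements on the series, on what has been measured and on what is new or still open speak of the compounds shown alone.

Of the compounds shown here, three sharing one core have been tested in an ADME assay on HEK293 cells (Homo sapiens) for cytotoxicity, read by luminescence, with a stated time of 72 h; on this read-out lower numbers stand for an effect already at smaller amounts and higher numbers for an effect only at larger amounts of compound. Compound 1 (`CCOC(=O)c1c(-c2cc(F)cc(OC)c2)[nH]c2cc(OC)ccc2c1=O`) gives only a limit, > 22000 nM. Compound 2 (`CCOC(=O)c1c(-c2cccc(OCC)c2)[nH]c2cc(OC)ccc2c1=O`) also gives only a limit, > 22000 nM. Compound 3 (`CCOC(=O)c1c(-c2cccc(C(F)(F)F)c2)[nH]c2cc(OC)ccc2c1=O`) likewise gives only a limit, > 22000 nM, so it has no number of its own, and the series stands at the limit of > 22000 nM in this assay, at which 3 of the 3 values shown sit. Compound 4 (`CCOC(=O)c1c(-c2cccc(Cl)c2)[nH]c2cc(OC)ccc2c1=O`) differs from compound 3 by chloro in place of trifluoromethyl on an aromatic carbon, with chloro in place of trifluoromethyl on an aromatic carbon. Among the measured compounds shown here, the steps that bear on this change are a step that the two limits leave unreadable from compound 2 to compound 3 and a step that the two limits leave unreadable from compound 1 to compound 2, and neither has a size to carry over. In this assay, a step that the limit leaves unreadable from compound 3 to compound 4 is therefore expected to stay within the scatter, with no direction expected. For compound 4 the estimated value is 25000 nM, with an expected range of 12000 nM to 50000 nM.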

Compound 4, half-maximal effective concentration: > 22000 nM
Compound 4: a limit, no number; the forecaster's own chance of this, stated with the estimate: 85%; the middle value lies beyond the limit too.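

No step can be read from compound 1, compound 2 or compound 3 to compound 4, as each pair gives only limits: the limit of > 22000 nM in this assay, at which 4 of the 4 values shown sit. The compounds shown leave open at what concentration any of them would reach a half-maximal effect, and whether the groups on the shared core differ at all.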